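Shortening the chain of compound 1

This account rests on a few compounds, and the source may have more. Where it says the series, first, only, none or still open, it means among the compounds named here.

Values in a functional assay on HCT-116 cells (Homo sapiens) for inhibition, read by MTT assay, with a stated time of 72 h; on this read-out higher numbers stand for weaker inhibition and lower numbers for stronger inhibition
Compound 1 `Nc1ncnc2c1c(-c1cnc3[nH]ccc3c1)nn2CCCCCCCCC(=O)NO` gives 5460 nM
Compound 2 `Nc1nc2cc(-c3nn(CCCCCCCCCC(=O)NO)c4ncnc(N)c34)ccc2o1` gives 23100 nM
Compound 3 `Nc1ncnc2c1c(-c1cnc3[nH]ccc3c1)nn2CCCCCCCCCC(=O)NO` gives 18700 nM

Compound 1 has the lowest number of the three, which means the strongest inhibition here. Compound 4 `Nc1ncnc2c1c(-c1cnc3[nH]ccc3c1)nn2CCC(=O)NO` keeps the core of compound 1, and the change hydroxycarbamoyl in place of 6-(hydroxycarbamoyl)hexyl on a saturated chain carbon, two bonds along the chain from an aromatic nitrogen leaves a far shorter chain. For the measured compounds named here, only one measured step alters chain length, and a 3.4-fold higher number from compound 1 to compound 3 (0.53 log units; beyond the scatter) is a modest lengthening. The step of a 1.2-fold lower number from compound 2 to compound 3 (0.09 log units; within the scatter) concerns another group and says nothing about the chain. Reversing a 3.4-fold higher number from compound 1 to compound 3 (0.53 log units; beyond the scatter) would hint at a lower number for compound 4, but one small change cannot be stretched so far, so no step beyond the scatter is expected in this assay here. The estimate gives a 1.3-fold higher number from compound 1 to compound 4 (0.11 log units; within the scatter) as the expected step. Compound 4 is estimated at 7000 nM with 1500 nM to 30000 nM as its range.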

Compound 4, half-maximal inhibitory concentration: > 150000 nM
Compound 4 ended at the assay's limit (the forecaster's own chance of this, stated with the estimate: 20%); middle value at least 21-fold (1.33 log units) from the limit.
By their numbers in this assay, from the lowest: compound 1; then compounds 3 and 2 (each within the scatter of the next). At a limit, above all of these: compound 4.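

In this assay, the shorter chain brings an at least 27-fold higher number from compound 1 to compound 4 (1.43 log units; beyond the scatter), far larger than the modest rise seen on lengthening, a 3.4-fold higher number from compound 1 to compound 3 (0.53 log units; beyond the scatter). On the shared core, then, the chain of compound 1 gives a lower number than both the longer chain of compound 3 and the much shorter one of compound 4, so shortening does not simply reverse the effect of lengthening. The value of compound 4 is a limit, not a number: the limit of > 150000 nM in this assay, at which 1 of the 4 values shown sits.

From the compounds shown here alone, how the numbers run for chains of intermediate length stays open. So does whether a carboxylic acid in place of hydroxycarbamoyl would keep any inhibition on the chain of compound 1.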